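The source may hold more compounds than are shown below. What is called first, only, known or untested is meant among the compounds shown, and "the series" means these compounds.

In an ADME assay on Raji cells (Homo sapiens) for cytotoxicity, read by luminescence, with a stated time of 72 h (on this read-out higher numbers stand for an effect only at larger amounts of compound and lower numbers for an effect already at smaller amounts), compound 1 `CCOC(=O)c1c(-c2cccc(OC)c2)[nH]c2cc(C(F)(F)F)ccc2c1=O` gives > 21500 nM, which is a limit of the assay and not a number. Compound 2 `CCOC(=O)c1c(-c2cccc(OC(F)(F)F)c2)[nH]c2cc(C(F)(F)F)ccc2c1=O` gives > 21500 nM, which is also only a limit. Compound 2 therefore has no exact value, and the two compounds share (the limit of > 21500 nM in this assay, at which 2 of the 2 values shown sit).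

Compound 3 `CCOC(=O)c1c(-c2cccc(Cl)c2)[nH]c2cc(C(F)(F)F)ccc2c1=O` keeps the core of compound 2 and changes one group, with chloro in place of trifluoromethoxy on an aromatic carbon. For the measured compounds named here, the only measured step that bears on this change is the one that alters the same substituent, a step that the two limits leave unreadable from compound 1 to compound 2. It gives no size to carry forward, but neither compound on that step produced a number in this assay. Compound 3 is therefore expected to behave in the same way, most likely reaching only the limit again. No step beyond the usual scatter is expected, and the estimated step is a step that the limit leaves unreadable from compound 2 to compound 3. The estimate for compound 3 is 22000 nM, with an expected range from 11000 nM to 44000 nM.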

Compound 3, half-maximal effective concentration: > 21500 nM
Compound 3 gave a limit, no number (the forecaster's own chance of this, stated with the estimate: 80%); the middle value does not contradict the limit.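

Compound 1, compound 2 and compound 3 all end at a limit of the assay and not at a number, so none of the steps between them can be read: the limit of > 21500 nM in this assay, at which 3 of the 3 values shown sit.

The compounds shown leave open how far apart these three truly lie and which change, if any, would give a readable value in this assay.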